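The source may report more compounds than this note shows. Statements on the series, on what has been measured and on what is new or still open speak of the compounds shown alone.

Values in a functional assay on HL-60 cells (Homo sapiens) for inhibition; on this read-out higher numbers stand for weaker inhibition and lower numbers for stronger inhibition:
- compound 1 `OC[C@H]1OC(n2cnc3c(-c4cc[nH]c4)ncnc32)[C@H](O)[C@@H]1O`: 3200 nM
- compound 2 `Cc1ccsc1-c1ncnc2c1ncn2C1O[C@H](CO)[C@@H](O)[C@H]1O`: 4500 nM
- compound 3 `OC[C@H]1OC(n2cnc3c(-c4ccc(F)cc4)ncnc32)[C@H](O)[C@@H]1O`: 6300 nM

Compound 3 at 6300 nM sits within the scatter of both other compounds, so the three values do not separate. The next compound is compound 4 `OC[C@H]1OC(n2cnc3c(-c4ccc(O)cc4)ncnc32)[C@H](O)[C@@H]1O`, which carries hydroxy in place of fluoro on an aromatic carbon, para to a large group: hydroxy in place of fluoro on an aromatic carbon.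

Among the compounds with values here, no measured step makes this exchange alone. The nearest evidence comes from swaps of the whole aromatic group on the shared core: a 1.4-fold higher number from compound 1 to compound 2 (0.15 log units; within the scatter), a 2.0-fold higher number from compound 1 to compound 3 (0.29 log units; within the scatter) and a 1.4-fold higher number from compound 2 to compound 3 (0.15 log units; within the scatter). All three remain within the scatter, but they say little about a hydroxy group, so the uncertainty stays wide.

With no measured basis for a direction, no change beyond the scatter is expected, and the estimate starts from compound 3 at 6300 nM. The expected step is a 1.3-fold lower number from compound 3 to compound 4 (0.10 log units; within the scatter). For compound 4 the estimated value is 5000 nM, with an expected range of 1500 nM to 16000 nM.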

Compound 4, half-maximal inhibitory concentration: 7600 nM
Beside the measured number, compound 4's estimate is 1.5-fold (0.18 log units) below it; the measured number falls inside the stated range.
By their numbers in this assay, from the lowest: compounds 1, 2, 3 and 4 (each within the scatter of the next, the first and the last beyond it).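

In this assay, within the data shown here, the first direct exchange at this position, hydroxy in place of fluoro, gives a 1.2-fold higher number from compound 3 to compound 4 (0.08 log units; within the scatter), so a hydrogen-bond donor and acceptor entering para to a large group leave the number within the scatter. Among these compounds, the wider swaps give a 1.7-fold higher number from compound 2 to compound 4 (0.23 log units; within the scatter), also within the scatter, and a 2.4-fold higher number from compound 1 to compound 4 (0.38 log units; beyond the scatter), the first step beyond the scatter, though only a modest one. No measurement available here accounts for these steps.

Still open, on these data alone, is whether an amine or a carboxylic acid at this same place on the phenyl ring would move the number beyond the scatter from 4-fluorophenyl. As far as these compounds go, it is also open whether a longer chain, such as methoxy or ethoxy, would do so.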